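A few compounds are considered here, and "the series" means these few. Any claim that something is new, unique, unknown or untested is made for them only; others in the source may bear on it.

Compound 1, `CC(C)c1cccc(C(C)C)c1OS(=O)(=O)NC(=O)O[C@@H]1C[C@H](C)CCC1C(C)C`, gives 21000 nM in an assay on liver for inhibition of sterol O-acyltransferase 1 (Rattus norvegicus), using microsomes; on this read-out lower numbers stand for stronger inhibition and higher numbers for weaker inhibition.
Compound 2, `CC(C)c1cccc(C(C)C)c1OS(=O)(=O)NC(=O)Oc1ccc(F)cc1`, gives only a limit, > 50000 nM, in this assay.
Compound 3, `CC(C)c1cccc(C(C)C)c1OS(=O)(=O)NC(=O)Oc1c(F)cccc1F`, gives 65000 nM in this assay.

Among the two readable numbers, compound 3 stands highest, the nearest one being compound 1 with a 3.1-fold higher number from compound 1 to compound 3 (0.49 log units; beyond the scatter). The value of compound 2 is a limit of the assay rather than a number, (the limit of > 50000 nM in this assay, at which 1 of the 3 values shown sits).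

Compound 4, `CC(C)c1ccccc1OC(=O)NS(=O)(=O)Oc1c(C(C)C)cccc1C(C)C`, differs from compound 3 in one place: 2-isopropylphenyl in place of 2,6-difluorophenyl on an oxygen next to a carbonyl group. Within the data shown here, no measured step exchanges one aromatic ring for another with a readable size: a step that the limit leaves unreadable from compound 2 to compound 3. What is measured is that replacing the 2-isopropyl-5-methylcyclohexyl group with a fluorinated aromatic ring raised the number, an at least 2.3-fold higher number from compound 1 to compound 2 (0.37 log units; beyond the scatter) and a 3.1-fold higher number from compound 1 to compound 3 (0.49 log units; beyond the scatter). Because compound 1 carries an isopropyl group and gave 21000 nM, the move to 2-isopropylphenyl is expected to lower the number somewhat in this assay, an estimated 1.6-fold lower number from compound 3 to compound 4 (0.21 log units; within the scatter). Compound 4 is therefore estimated at 40000 nM, with a range from 15000 nM to 100000 nM.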

Compound 4, half-maximal inhibitory concentration: > 50000 nM
Compound 4: no number, only a limit; the forecaster's own chance of this, stated with the estimate: 30%; middle value at least 1.2-fold (0.09 log units) away from the limit.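

Compound 4 gives only a limit, not a number, so its steps to compound 2 and compound 3 cannot be read: the limit of > 50000 nM in this assay, at which 2 of the 4 values shown sit.

The step that can be read is an at least 2.3-fold higher number from compound 1 to compound 4 (0.37 log units; beyond the scatter). In this assay, keeping an isopropyl group therefore does not preserve the level of compound 1 once the saturated 2-isopropyl-5-methylcyclohexyl group gives way to an aromatic ring, and this aromatic ring carries no fluorine, unlike those of compound 2 and compound 3.

From the compounds shown here alone, the order of compound 2, compound 3 and compound 4 among themselves stays open. Also open, going by these compounds, is whether a plain cyclohexyl group, a longer carbon chain, or a phenyl ring carrying an amine or a carboxylic acid at this place would give stronger inhibition than compound 1.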